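The compounds below may be only part of what the source reports. "The series", "measured", "known", "first", "only" and "open" are said of these compounds alone.

Three analogues that share one core and differ only in the aromatic group carried on the amine have been tested in a functional assay on BMMC cells (Mus musculus, strain C57BL/6) for inhibition, with stated times of 5 days and 48 h; on this read-out lower numbers stand for stronger inhibition and higher numbers for weaker inhibition. Compound 1 `C=C1CC[C@@H]2[C@](C)(CNCc3ccc(OC)cc3)[C@H](O)CC[C@@]2(C)[C@@H]1/C=C/C1=CCOC1=O` gives 750 nM there. Compound 2 `C=C1CC[C@@H]2[C@](C)(CNCc3ccc(F)cc3)[C@H](O)CC[C@@]2(C)[C@@H]1/C=C/C1=CCOC1=O` gives 350 nM, and compound 3 `C=C1CC[C@@H]2[C@](C)(CNCc3ccc(C#N)cc3)[C@H](O)CC[C@@]2(C)[C@@H]1/C=C/C1=CCOC1=O` gives 1130 nM. Among these three numbers compound 3 has the highest; its distance from compound 1 is a 1.5-fold higher number from compound 1 to compound 3 (0.18 log units; within the scatter), which lies within the usual scatter, while its distance from compound 2 is a 3.2-fold higher number from compound 2 to compound 3 (0.51 log units; beyond the scatter), which lies beyond it.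

Compound 4 `C=C1CC[C@@H]2[C@](C)(CNCc3ccncc3)[C@H](O)CC[C@@]2(C)[C@@H]1/C=C/C1=CCOC1=O` differs from compound 3 in one place: pyridin-4-yl in place of 4-cyanophenyl on a saturated chain carbon bound to an amine nitrogen. Among the measured compounds shown here, no measured step exchanges the whole ring in this way, so none bears on it directly. The two steps that end at compound 3, a 1.5-fold higher number from compound 1 to compound 3 (0.18 log units; within the scatter) and a 3.2-fold higher number from compound 2 to compound 3 (0.51 log units; beyond the scatter), only swap the group sitting on the ring, and neither is more than modest. The step from compound 3 to compound 4 is therefore expected to be of similar size, with the direction uncertain, and it is estimated as a 1.4-fold lower number from compound 3 to compound 4 (0.15 log units; within the scatter). For compound 4 in this assay the expected value is 800 nM, within a range from 250 nM to 2500 nM.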

Compound 4, half-maximal inhibitory concentration: 2030 nM
Estimate against measurement, compound 4: 2.5-fold (0.40 log units) below; the measured number falls inside the stated range.
By their numbers in this assay, from the lowest: compound 2; then compounds 1, 3 and 4 (each within the scatter of the next, the first and the last beyond it).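

Unlike the earlier steps, which only swap the group on the ring, this change replaces the ring itself, putting a nitrogen into it and dropping the nitrile, and in this assay the result cannot be told apart from compound 3: a 1.8-fold higher number from compound 3 to compound 4 (0.25 log units; within the scatter). Against the other two rings the same exchange does register, with a 2.7-fold higher number from compound 1 to compound 4 (0.43 log units; beyond the scatter) and, the widest gap in the set so far though still modest, a 5.8-fold higher number from compound 2 to compound 4 (0.76 log units; beyond the scatter), so compound 2 keeps the lowest number and its 4-fluorophenyl group remains the best of the four groups at this place. Nothing available explains why pyridin-4-yl sits with 4-cyanophenyl rather than with 4-fluorophenyl.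

As far as these compounds go, all four groups are six-membered aromatic rings on a saturated chain carbon bound to an amine nitrogen, so it remains open how an unsubstituted phenyl or a saturated cyclohexyl group would read there. With the benzyl-type link held constant throughout, a longer chain between the amine and the ring is also an open question, as is whether the 4-fluorophenyl advantage would survive it.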